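Swapping the Lactam at the Aryl Ring

A few compounds are considered here, and "the series" means these few. Any claim that something is new, unique, unknown or untested is made for them only; others in the source may bear on it.

This account follows a pair of amides built on one shared core. Compound 1 `CC(C(=O)Nc1cc(C2CC2)[nH]n1)c1ccc(N2C(=O)CCC2C)cc1` was tested in a functional assay on A2780 cells (Homo sapiens) for inhibition (on this read-out higher numbers stand for weaker inhibition and lower numbers for stronger inhibition), where compound 1 gives 6400 nM. Going by the values given here, the only other number comes from compound 2 `C[C@H](C(=O)Nc1cc(C2CC2)[nH]n1)c1ccc(N2Cc3ccccc3C2=O)cc1`, which in this assay gives 1020 nM. Compound 1 therefore stands highest of the two values shown, and its nearest neighbour, compound 2, sits beyond the usual scatter.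

Among the compounds with values here, no step between compound 1 and compound 2 changes a single place, so nothing measured yet isolates the group on the aromatic carbon. Compound 3 `CC(C(=O)Nc1cc(C2CC2)[nH]n1)c1ccc(N2CCCS2(=O)=O)cc1` differs from compound 1 as follows: a group of 7 heavy atoms (3 carbon, 1 nitrogen, 2 oxygen, 1 sulfur; one five-membered non-aromatic ring with 2 hetero atoms) in place of a group of 7 heavy atoms (5 carbon, 1 nitrogen, 1 oxygen; one five-membered non-aromatic ring with 1 hetero atom), on an aromatic carbon. Both groups are of the same size, and both are five-membered non-aromatic rings, but the entering group carries the sulfur and the second oxygen.

Within the data shown here, with no measured step of this kind to lean on, only a modest step is expected from compound 1 to compound 3, if any beyond the scatter, as a 1.3-fold lower number from compound 1 to compound 3 (0.11 log units; within the scatter) states. Compound 3 is therefore estimated at 5000 nM in this assay, with a range from 1500 nM to 16000 nM.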

Compound 3, half-maximal inhibitory concentration: 5240 nM
Beside the measured number, compound 3's estimate is 1.0-fold (0.02 log units) below it, and the stated range covers the measured number.
By their numbers in this assay, from the lowest: compound 2; then compounds 3 and 1 (each within the scatter of the next).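

Read in this assay the exchange gives a 1.2-fold lower number from compound 1 to compound 3 (0.09 log units; within the scatter) and is the first step in this account that alters one place alone. On an aromatic carbon para to a large group, a five-membered non-aromatic ring with 2 hetero atoms, including the sulfur and the second oxygen, can thus stand in for the five-membered non-aromatic ring with 1 hetero atom with no change beyond the scatter. The 2 hydrogen-bond acceptors of the entering group, against the 1 of the group that leaves, also bring no difference that this read-out can separate, and no measurement on hand offers an explanation for this.

The compounds shown leave open whether a ring is needed on this aromatic carbon at all, since a simple amine, a carboxylic acid or a longer chain there would test that directly. Going by these compounds alone, they also leave open what sets compound 2 apart, as it differs from compound 1 in more than one place and no single-place step connects the two.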